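Swapping the Phenyl Substituent in a Urea ACAT Inhibitor Series

The compounds below may be only part of what the source reports. "The series", "measured", "known", "first", "only" and "open" are said of these compounds alone.

Three ureas sharing one core have been measured in an assay on microsomes for inhibition of acyl-CoA:cholesterol acyltransferase (Oryctolagus cuniculus); on this read-out lower numbers stand for stronger inhibition and higher numbers for weaker inhibition. Compound 1 `Cc1cccc(C2(CNC(=O)Nc3c(C(C)C)cccc3C(C)C)CCCC2)c1` gives 15 nM. Compound 2 `CC(C)c1ccc(C2(CNC(=O)Nc3c(C(C)C)cccc3C(C)C)CCCC2)cc1` gives 48 nM, the highest number of the three: against compound 3 `CC(C)c1cccc(C(C)C)c1NC(=O)NCC1(c2ccc(F)cc2)CCCC1`, which gives 23 nM, the closest, the step is a 2.1-fold lower number from compound 2 to compound 3 (0.32 log units; beyond the scatter), and against compound 1 it is a 3.2-fold higher number from compound 1 to compound 2 (0.51 log units; beyond the scatter) in the other direction. Compound 1 and compound 3 sit close together, a 1.5-fold higher number from compound 1 to compound 3 (0.19 log units; within the scatter).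

The unmeasured compound 4 `CC(C)c1cccc(C(C)C)c1NC(=O)NCC1(c2ccc([N+](=O)[O-])cc2)CCCC1` differs from compound 2 in one place: nitro in place of isopropyl on an aromatic carbon. For the measured compounds named here, the step that bears most directly on this change is the one from compound 2 to compound 3, where a fluoro took the place of the same isopropyl and gave a 2.1-fold lower number from compound 2 to compound 3 (0.32 log units; beyond the scatter). That step shows that removing the isopropyl from this position does not cost potency and can bring the number down modestly. Going by the values given here, no measured compound carries a nitro, so the size of the effect of that particular group is unknown.

The expectation for compound 4 in this assay is therefore a modest move toward a lower number, a 1.4-fold lower number from compound 2 to compound 4 (0.14 log units; within the scatter), an estimate that may well land within the scatter. Compound 4 is estimated at 35 nM, with a range from 12 nM to 100 nM.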

Compound 4, half-maximal inhibitory concentration: 131 nM
The estimate for compound 4 lay 3.7-fold (0.57 log units) below the measured number; measured number outside the range, above it.
By their numbers in this assay, from the lowest: compounds 1 and 3 (each within the scatter of the next); then compound 2; then compound 4.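

In this assay, replacing the same isopropyl does not push the number one way: fluoro brings it down (a 2.1-fold lower number from compound 2 to compound 3 (0.32 log units; beyond the scatter)), while nitro, which has as many heavy atoms as the isopropyl and adds hydrogen-bond acceptors, sends it up (a 2.7-fold higher number from compound 2 to compound 4 (0.44 log units; beyond the scatter)). So losing the isopropyl does not settle the outcome, and what enters at this position matters, as the direct exchange of fluoro for nitro shows (a 5.7-fold higher number from compound 3 to compound 4 (0.76 log units; beyond the scatter)), and the 4-nitrophenyl compound also stands well apart from the 3-methylphenyl compound (an 8.7-fold higher number from compound 1 to compound 4 (0.94 log units; beyond the scatter)). No measurement here explains why fluoro and nitro part ways.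

Going by these compounds, with only isopropyl, fluoro and nitro at this position, it remains open whether an amine, a methoxy group or a carboxylic acid there would fall nearer compound 3 or compound 4. On these data alone, it also remains open whether nitro would give a similar number if it stood on the ring where compound 1 carries its methyl.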